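This account rests on a few compounds, and the source may have more. Where it says the series, first, only, none or still open, it means among the compounds named here.

Measured so far in a functional assay on KB cells (Homo sapiens) for inhibition; a higher number here means a weaker inhibitor, a lower number a stronger inhibitor:

Compound 1, `OCCOCn1c(S)nc2cc(Cl)c(Cl)cc21`, gives > 100000 nM, which is a limit of the assay and not a number.
Compound 2, `OCCOCn1c(S)nc2c(Cl)c(Cl)ccc21`, gives > 100000 nM, again a limit of the assay.
Compound 3, `OCCOCn1c(Br)nc2cc(Cl)c(Cl)cc21`, gives > 100000 nM, once more a limit of the assay.

Compound 1 and compound 3 share one core and differ in a single place: bromo in place of sulfanyl on an aromatic carbon
The step this change made, a step that the two limits leave unreadable from compound 1 to compound 3, cannot be read, because both compounds sit at the limit of > 100000 nM in this assay, at which 3 of the 3 values shown sit. Compound 2 has the same atoms as compound 1 joined differently; the difference between the two cores is not broken down here.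

Compound 4, `OCCOCn1c(Br)nc2c(Cl)c(Cl)ccc21`, has not yet been tested in this assay. It stands to compound 2 as compound 3 stands to compound 1, carrying the same change: bromo in place of sulfanyl on an aromatic carbon
The surroundings of the change are described in identical words for both pairs, so the change is the same one, made on the other core.

Among the compounds with values here, for the step from compound 2 to compound 4 the expectation is a step that the limit leaves unreadable from compound 2 to compound 4, which rests on the fact that every value measured so far, including that of compound 2, sits at the limit of > 100000 nM in this assay, at which 3 of the 3 values shown sit. For compound 4 the estimated value in this assay is therefore 150000 nM, with a range from 50000 nM to 500000 nM, and most likely the assay will again report only a limit.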

Compound 4, half-maximal inhibitory concentration: > 100000 nM
Compound 4 ended at the assay's limit; the forecaster's own chance of this, stated with the estimate: 85%; the middle value is on the limit's open side.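

No size can be read for the step between compound 2 and compound 4, because neither compound gives a number in this assay: the limit of > 100000 nM in this assay, at which 4 of the 4 values shown sit.

The compounds shown leave open whether swapping sulfanyl for bromo changes inhibition at all on either core, and whether any close relative of these compounds would give a true number in this assay rather than a limit.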